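The source may hold more compounds than are shown below. What is called first, only, known or untested is meant among the compounds shown, and "the series" means these compounds.

In a functional assay on A549 cells (Homo sapiens) for inhibition, with a stated time of 48 h, tested at 50 uM (a lower number here means less inhibition of growth, a higher number more inhibition of growth at the concentration tested), two compounds sharing one core have been measured so far: compound 1 (`C=C[C@@](C)(/C=C/c1ccc(OC(=O)CCC)cc1)CCC=C(C)C`) gives 50%, and compound 2 (`C=C[C@@](C)(/C=C/c1ccc(OC(=O)CCCCC)cc1)CCC=C(C)C`) gives 58%. Compound 2 therefore stands within the scatter of compound 1, and the two cannot be ranked. Compound 3 (`C=C[C@@](C)(/C=C/c1ccc(OC(=O)CCCCCCC)cc1)CCC=C(C)C`) differs from compound 2 by one change on the same chain: ethyl in place of hydrogen on a saturated chain carbon, five bonds along the chain from a carbonyl carbon. For the measured compounds named here, only one measured step bears on this, the same ethyl in place of hydrogen on a saturated chain carbon, but three bonds along the chain from a carbonyl carbon. That step gave a number 8 percentage points higher from compound 1 to compound 2 (within the scatter). With so small a precedent, no change beyond the scatter is expected in this assay. The expected step is a number 2 percentage points higher from compound 2 to compound 3 (within the scatter). For compound 3 the estimated value is 60%, with an expected range of 45% to 75%.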

Compound 3, percent growth inhibition at one concentration: 15%
The estimate for compound 3 lay 45 percentage points above the measured number; the measured number lies below the stated range.
By their numbers in this assay, from the lowest: compound 3; then compounds 1 and 2 (each within the scatter of the next).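

In this assay, ethyl in place of hydrogen on a saturated chain carbon, five bonds along the chain from a carbonyl carbon, gave a number 43 percentage points lower from compound 2 to compound 3 (beyond the scatter) and so moved the number far beyond the scatter, which the same group three bonds along the chain had not done. The larger extension of the same chain gave a number 35 percentage points lower from compound 1 to compound 3 (beyond the scatter), so the chain of compound 3 stands apart from those of compound 1 and compound 2. Nothing in the data shown accounts for this fall.

The compounds shown leave open whether the number falls abruptly or gradually as the chain grows from that of compound 2 to that of compound 3. They also leave open whether a longer chain stays as low, and whether an amine or a carboxylic acid at the chain end would restore the number.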